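The compounds below may be only part of what the source reports. "The series", "measured", "known", "first", "only" and "open" are said of these compounds alone.

In an assay on microsomes from liver for inhibition of 3-hydroxy-3-methylglutaryl-coenzyme A reductase (Rattus norvegicus) (a lower number here means a stronger inhibitor, a higher number a weaker inhibitor), compound 3 `CC(C)c1c(C(=O)N2CCC[C@H](c3ccccc3)C2)nn(-c2ccc(F)cc2)c1OC[C@@H](O)C[C@@H](O)CC(=O)O` gives 4.8 nM, the lowest number of the three measured compounds. Compound 1 `CCN(Cc1ccccc1)C(=O)c1nn(-c2ccc(F)cc2)c(OC[C@@H](O)C[C@@H](O)CC(=O)O)c1C(C)C` gives 14 nM and compound 2 `Cc1ccc(CNC(=O)c2nn(-c3ccc(F)cc3)c(OC[C@@H](O)C[C@@H](O)CC(=O)O)c2C(C)C)cc1` gives 15 nM; the step between them, a 1.1-fold higher number from compound 1 to compound 2 (0.03 log units; within the scatter), is within the scatter. Compound 4 `CC(C)c1c(C(=O)NCc2ccccn2)nn(-c2ccc(F)cc2)c1OC[C@@H](O)C[C@@H](O)CC(=O)O` carries ((pyridin-2-yl)methyl)amino in place of 3-phenylpiperidin-1-yl on a carbonyl carbon. Among the compounds with values here, two measured steps bear on this change and both run the other way: a 2.9-fold lower number from compound 1 to compound 3 (0.46 log units; beyond the scatter) and a 3.1-fold lower number from compound 2 to compound 3 (0.49 log units; beyond the scatter), each a modest lowering of the number when the 3-phenylpiperidin-1-yl group replaced the benzyl(ethyl)amino or (4-methylbenzyl)amino group. Since compound 4 returns to an amino group of that kind, a modest rise in the number is expected, a 3.1-fold higher number from compound 3 to compound 4 (0.49 log units; beyond the scatter). Compound 4 is therefore estimated at 15 nM, with a range from 6 nM to 40 nM.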

Compound 4, half-maximal inhibitory concentration: 25 nM
Compound 4: the middle estimate sits 1.7-fold (0.22 log units) below what was measured; the measured number falls inside the stated range.
By their numbers in this assay, from the lowest: compound 3; then compounds 1, 2 and 4 (each within the scatter of the next).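

In this assay, the ring nitrogen makes no difference that can be read here: pyridin-2-yl in place of 4-methylphenyl stays within the scatter (a 1.7-fold higher number from compound 2 to compound 4 (0.22 log units; within the scatter)). ((Pyridin-2-yl)methyl)amino in place of benzyl(ethyl)amino also stays within the scatter (a 1.8-fold higher number from compound 1 to compound 4 (0.25 log units; within the scatter)). Only the step from 3-phenylpiperidin-1-yl lies beyond the scatter (a 5.2-fold higher number from compound 3 to compound 4 (0.72 log units; beyond the scatter)), so among these four groups on the carbonyl carbon, that group alone stands apart.

No evidence given here accounts for this separation. From the compounds shown here alone, whether an unsubstituted piperidin-1-yl or a morpholin-4-yl on this carbonyl carbon would match the number of compound 3 stays open.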